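A few compounds are considered here, and "the series" means these few. Any claim that something is new, unique, unknown or untested is made for them only; others in the source may bear on it.

In a functional assay on MCF7 cells (Homo sapiens) for cytotoxicity, read by MTT assay, with a stated time of 48 h (on this read-out higher numbers stand for weaker inhibition and lower numbers for stronger inhibition), compound 2 (`COc1cc(-c2cc(COCc3cn(Cc4cc(-c5ccc(C)cc5)cnc4Cl)nn3)on2)cc(OC)c1OC`) gives 58400 nM and stands level with compound 1 (`COc1cc(COCc2cn(Cc3cc(C)cnc3Cl)nn2)cc(OC)c1OC`) at 67400 nM within the scatter. Compound 3 (`COc1cc(COCc2cn(Cc3cc(-c4ccc(C)cc4)cnc3Cl)nn2)cc(OC)c1OC`) gives 146000 nM as the highest number of the three, and it lies beyond the scatter from both of the others.

The change to compound 4 (`COc1cc(-c2cc(COCc3cn(Cc4cc(-c5ccc(F)cc5)cnc4Cl)nn3)on2)cc(OC)c1OC`) is fluoro in place of methyl on an aromatic carbon, para to a large group, and it turns 4-methylphenyl to 4-fluorophenyl.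

Going by the values given here, only one measured step bears on this, and only indirectly: a 2.2-fold higher number from compound 1 to compound 3 (0.34 log units; beyond the scatter) is modest and has 4-methylphenyl in place of methyl. That step concerns the whole 4-methylphenyl group and not the methyl at its end, so it sets no size for the present exchange. Among the compounds with values here, no measured pair exchanges methyl for fluoro, and the series holds only three numbers. A step within the scatter is therefore expected in this assay with no direction favoured. The estimated step is a 1.0-fold higher number from compound 2 to compound 4 (0.01 log units; within the scatter) as the working expectation. For compound 4 the expected value is 60000 nM with an estimated range from 28000 nM to 130000 nM in this assay.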

Compound 4, half-maximal inhibitory concentration: 76400 nM
The estimate for compound 4 lay 1.3-fold (0.10 log units) below the measured number; the measured number falls inside the stated range.
By their numbers in this assay, from the lowest: compounds 2, 1, 4 and 3 (each within the scatter of the next, the first and the last beyond it).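

Working note on the para position: in this assay, the first direct reading of fluoro in place of methyl on this aromatic carbon, para to a large group, is a 1.3-fold higher number from compound 2 to compound 4 (0.12 log units; within the scatter). The step lies within the scatter, so compound 2 and compound 4 stand level, and on the core of compound 2 this exchange, 4-methylphenyl to 4-fluorophenyl, gives no separable shift in this one pair. Nothing available explains this reading or connects it to any property of either group.

The compounds shown leave open whether an amine, a hydroxyl or a carboxylic acid on the same aromatic carbon would carry the number beyond the scatter, or whether the level reading extends to such groups at all. Also open, going by these compounds, is whether the same exchange of methyl for fluoro would stay within the scatter on the core of compound 3, since one pair on one core sets no rule for the series.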